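This account rests on a few compounds, and the source may have more. Where it says the series, first, only, none or still open, it means among the compounds named here.

Of the compounds shown here, three have been measured in an assay on isolated protein for inhibition of DNA topoisomerase 1 (Homo sapiens), tested at 20 uM; on this read-out lower numbers stand for a weaker effect and higher numbers for a stronger effect at the one concentration tested. Compound 1 `COc1cc(O)ccc1/C=C/C(=O)c1ccc(NC(C)=O)cc1` gives 17.3%, compound 2 `O=C(/C=C/c1ccc(N2CCCC2)cc1)c1ccc(O)cc1` gives 60%, and compound 3 `COc1ccc(/C=C/C(=O)c2ccc(O)cc2)cc1Br` gives 6.6%. Compound 2 therefore stands highest of the three: its nearest neighbour is compound 1, which lies lower by a gap beyond the usual scatter, and compound 3 lies lower still, also beyond the scatter.

Compound 4 `O=C(/C=C/c1ccc(N2CCCC2)cc1)c1ccc(F)cc1` has not yet been measured in this assay. It differs from compound 2 in one place: fluoro in place of hydroxy on an aromatic carbon. For the measured compounds named here, no pair of measured compounds differs in just this way, so no measured step shows what this change does, and compound 1 and compound 3 each differ from compound 2 in more than one place, so they give no direct guide either. On the basis of the change alone, the step is expected to be a loss, estimated as a number 25 percentage points lower from compound 2 to compound 4 (beyond the scatter). Going by the values given here, compound 4 is accordingly expected to give about 35% in this assay, within a range from 10% to 62%, the width reflecting that no measured step covers this change.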

Compound 4, a percentage reported as inhibition, at one concentration (the size of the read-out at that concentration, not a potency): 73.1%
Compound 4: middle estimate off by 38.1 percentage points, on the low side; the whole stated range lies below it.
By their numbers in this assay, from the lowest: compound 3; then compound 1; then compound 2; then compound 4.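

In this assay, the change from 4-hydroxyphenyl to 4-fluorophenyl gives a number 13.1 percentage points higher from compound 2 to compound 4 (beyond the scatter), so at this place on an aromatic carbon, the hydroxy with its hydrogen-bond donor and acceptor is not needed to keep the read-out in this pair. For the compounds shown here, this is the first measured step at this place, and it shows a gain where the earlier compounds could show nothing about the change, though it rests on the single pair. No measurement beyond the read-out itself bears on why the step runs in this direction.

On these data alone, whether a chloro, an amine or a carboxylic acid at this place would match the fluoro remains open. As far as these compounds go, it is equally open whether the same change would run the same way on the core of compound 3.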